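Swapping methoxy for nitro: an estimate for compound 3

This account rests on a few compounds, and the source may have more. Where it says the series, first, only, none or still open, it means among the compounds named here.

Going by the values given here, in a functional assay on HeLa cells (Homo sapiens) for antiproliferative activity, read by MTT assay, with a stated time of 48 h (a lower number here means a stronger inhibitor, a higher number a weaker inhibitor), compound 1 `COc1ccc2nc(NC(c3cn(-c4ccccc4)nc3-c3ccc([N+](=O)[O-])cc3)c3c(O)ccc4ccccc34)sc2c1` gives 5540 nM and compound 2 `COc1ccc(-c2nn(-c3ccccc3)cc2C(Nc2nc3ccc(OC)cc3s2)c2c(O)ccc3ccccc23)cc1` gives 9240 nM, so compound 2 stands within the usual scatter of the only other number. Compound 3 `COc1ccc2nc(NC(c3cn(-c4ccccc4)nc3-c3cccc([N+](=O)[O-])c3)c3c(O)ccc4ccccc34)sc2c1` differs from compound 2 by one group: 3-nitrophenyl in place of 4-methoxyphenyl on an aromatic carbon. Methoxy in place of nitro on an aromatic carbon gave a 1.7-fold higher number from compound 1 to compound 2 (0.22 log units; within the scatter), the one measured step that bears on this change. In this assay the expected step is therefore small, a 1.4-fold lower number from compound 2 to compound 3 (0.15 log units; within the scatter), and nothing beyond the scatter. For compound 3 the estimated value is 6500 nM, with an expected range of 3000 nM to 14000 nM.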

Compound 3, half-maximal inhibitory concentration: 6140 nM
Estimate against measurement, compound 3: 1.1-fold (0.02 log units) above; low and high end bracket the measured number.
By their numbers in this assay, from the lowest: compounds 1, 3 and 2 (each within the scatter of the next).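

In this assay the step of a 1.1-fold higher number from compound 1 to compound 3 (0.04 log units; within the scatter) shows that 3-nitrophenyl and 4-nitrophenyl cannot be told apart at this position on the five-membered ring. The step of a 1.5-fold lower number from compound 2 to compound 3 (0.18 log units; within the scatter) adds that 3-nitrophenyl and 4-methoxyphenyl cannot be told apart either, so all three groups shown here read alike. No measurement shown here explains this flat picture.

On these data alone, whether an amine or a carboxylic acid on this phenyl ring would move the number beyond the scatter stays open, as does the effect of replacing the ring with a short alkyl chain.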